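This account rests on a few compounds, and the source may have more. Where it says the series, first, only, none or still open, it means among the compounds named here.

Compound 1 `O=C(Cn1cc(COc2nc(-c3ccccc3)nc3nc(C(F)(F)F)ccc23)nn1)Nc1ccccc1` gives 650 nM in a functional assay on MDA-MB-231 cells (Homo sapiens) for antiproliferative activity, read by sulforhodamine B assay, with a stated time of 48 h; on this read-out lower numbers stand for stronger inhibition of growth and higher numbers for weaker inhibition of growth.
Compound 2 `CCCCCCCCCCn1cc(COc2nc(-c3ccccc3)nc3nc(C(F)(F)F)ccc23)nn1` gives 1050 nM in this assay.
Compound 3 `CCCCCCCCn1cc(COc2nc(-c3ccccc3)nc3nc(C(F)(F)F)ccc23)nn1` gives 570 nM in this assay.

Compound 3 shows the smallest number of the three, yet the steps of a 1.1-fold lower number from compound 1 to compound 3 (0.06 log units; within the scatter) and a 1.8-fold lower number from compound 2 to compound 3 (0.27 log units; within the scatter) both lie within the usual scatter, so the three compounds cannot be told apart on these figures. Compound 4 `COc1cc(-n2cc(COc3nc(-c4ccccc4)nc4nc(C(F)(F)F)ccc34)nn2)cc(OC)c1OC` differs from compound 3 by 3,4,5-trimethoxyphenyl in place of octyl on an aromatic nitrogen. For the measured compounds named here, the two steps that change the group on this same aromatic nitrogen, a 1.1-fold lower number from compound 1 to compound 3 (0.06 log units; within the scatter) and a 1.8-fold lower number from compound 2 to compound 3 (0.27 log units; within the scatter), were both within the scatter, which speaks for little sensitivity at this position, though no measured step brings in an aromatic ring there. The expected step of a 1.1-fold higher number from compound 3 to compound 4 (0.02 log units; within the scatter) is therefore none beyond the scatter. Compound 4 is estimated at 600 nM, with a range from 150 nM to 2500 nM.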

Compound 4, concentration for 50% growth inhibition: 240 nM
Beside the measured number, compound 4's estimate is 2.5-fold (0.40 log units) above it; the measured number falls inside the stated range.
By their numbers in this assay, from the lowest: compound 4; then compounds 3, 1 and 2 (each within the scatter of the next).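

The group on this aromatic nitrogen does matter: with 3,4,5-trimethoxyphenyl, the only aromatic ring bound directly to this nitrogen among these compounds, the number falls beyond the scatter in all three steps, with a 2.4-fold lower number from compound 3 to compound 4 (0.38 log units; beyond the scatter), a 4.4-fold lower number from compound 2 to compound 4 (0.64 log units; beyond the scatter) and a 2.7-fold lower number from compound 1 to compound 4 (0.43 log units; beyond the scatter), all modest. The earlier lack of sensitivity therefore held only among octyl, decyl and (phenylcarbamoyl)methyl. No supporting data explain this gain.

A plain phenyl ring here would show whether the ring alone or its methoxy groups carry the step. Shorter chains such as butyl, or a chain ending in an amine, also remain open.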